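Replacing Phenoxy with Nitro in a Small Series

This account rests on a few compounds, and the source may have more. Where it says the series, first, only, none or still open, it means among the compounds named here.

- Compound 1 `C=C1CCC2[C@](C)(CO)[C@H](O)CC[C@@]2(C)[C@@H]1CCn1cnc2c(N)ncnc21`: > 100000 nM (a limit)
- Compound 2 `C=C1CCC2[C@](C)(CO)[C@H](O)CC[C@@]2(C)[C@@H]1CCOc1cccc2ccccc12`: 44700 nM
- Compound 3 `C=C1CCC2[C@](C)(CO)[C@H](O)CC[C@@]2(C)[C@@H]1CCOc1ccc(Oc2ccccc2)cc1`: 12800 nM

All three compounds were tested in a functional assay on RAW264.7 cells (Mus musculus) for inhibition, read by Griess assay, with stated times of 3 h and 24 h; on this read-out higher numbers stand for weaker inhibition and lower numbers for stronger inhibition. Compound 1 gives only a limit of the assay, > 100000 nM.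

Of the two compounds with actual numbers, compound 3 at 12800 nM stands lower and is therefore the stronger inhibitor of the pair. The gap to compound 2 at 44700 nM lies beyond the scatter.

Compound 4 `C=C1CCC2[C@](C)(CO)[C@H](O)CC[C@@]2(C)[C@@H]1CCOc1ccc([N+](=O)[O-])cc1` keeps the shared core of compound 3 but has nitro in place of phenoxy on an aromatic carbon, para to a large group (nitro in place of phenoxy on an aromatic carbon). For the measured compounds named here, no measured pair differs in only one place, so any forecast remains loose. Compound 3, at 12800 nM, is the only measured compound carrying phenoxy and has the lowest number among those shown. Losing that group is therefore expected to move the number upward, towards weaker inhibition, and probably beyond the scatter. The expected change in this assay is a 2.3-fold higher number from compound 3 to compound 4 (0.37 log units; beyond the scatter). In this assay the expected value of compound 4 is 30000 nM, with an estimated range from 11000 nM to 90000 nM.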

Compound 4, half-maximal inhibitory concentration: 3380 nM
Beside the measured number, compound 4's estimate is 8.9-fold (0.95 log units) above it; measured number outside the range, below it.
By their numbers in this assay, from the lowest: compound 4; then compound 3; then compound 2. At a limit, above all of these: compound 1.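

At this place, on an aromatic carbon para to a large group, the phenoxy group with its six-membered aromatic ring is not needed to reach the lowest number shown: in this assay, nitro in place of phenoxy gives a 3.8-fold lower number from compound 3 to compound 4 (0.58 log units; beyond the scatter). Compound 3 therefore no longer marks the low end of the series, and a change from 7 heavy atoms to 3 heavy atoms at this place goes with stronger inhibition, not weaker, for this one pair. The compounds shown give no measured property that would account for this step, and the single limit among the values does not bear on it.

As far as these compounds go, what remains open is whether the step belongs to nitro itself or would also appear with other groups on the same carbon, such as an amine, a carboxylic acid or a methoxy group. From the compounds shown here alone, it is equally open whether nitro would give a similar number on another carbon of the ring, since this single pair speaks only for the place it occupies in compound 4.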